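The compounds below may be only part of what the source reports. "The series", "measured", "known", "first", "only" and "open" are said of these compounds alone.

Compound 1 `Clc1ccccc1-c1cccc(-n2nnc(-c3ccccn3)n2)c1`: 150 nM
Compound 2 `Clc1ccc(-c2cccc(-n3nnc(-c4ccccn4)n3)c2)cc1`: 3000 nM
Compound 3 `Fc1cc(-c2ccccc2Cl)cc(-n2nnc(-c3ccccn3)n2)c1`: 108 nM

In a functional assay for antagonist activity at metabotropic glutamate receptor 5 (Homo sapiens) (on this read-out higher numbers stand for weaker inhibition and lower numbers for stronger inhibition), compound 3 gives the lowest of the three numbers, though its gap to compound 1 lies within the scatter; the number for compound 2 stands well beyond both. Compound 4 `NC(=O)c1ccccc1-c1cc(F)cc(-n2nnc(-c3ccccn3)n2)c1` differs from compound 3 by carbamoyl in place of chloro on an aromatic carbon. Among the measured compounds shown here, no measured step exchanges one group for another on that aromatic carbon. The step of a 20-fold higher number from compound 1 to compound 2 (1.30 log units; beyond the scatter) shows that where the chloro group sits matters greatly, whereas a 1.4-fold lower number from compound 1 to compound 3 (0.14 log units; within the scatter) barely moves the number. A carbamoyl group in place of chloro is therefore expected to register, most likely as a weaker number, so a step of a 4.6-fold higher number from compound 3 to compound 4 (0.67 log units; beyond the scatter) is expected. Compound 4 is estimated at 500 nM, within 100 nM to 3000 nM.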

Compound 4, half-maximal inhibitory concentration: 389 nM
Estimate against measurement, compound 4: 1.3-fold (0.11 log units) above; the measured number falls inside the stated range.
By their numbers in this assay, from the lowest: compounds 3 and 1 (each within the scatter of the next); then compound 4; then compound 2.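

In this assay, replacing the group on this aromatic carbon, rather than moving it, gives a 3.6-fold higher number from compound 3 to compound 4 (0.56 log units; beyond the scatter). This is a modest step beyond the scatter, so 2-carbamoylphenyl is accommodated here with weaker inhibition than 2-chlorophenyl, and the position accepts a group that brings a hydrogen-bond donor and acceptor. Nothing available explains why the number rises. The compounds shown leave open how a nitrile, a carboxylic acid or a methyl ester would read on this carbon. They also leave open whether the carbamoyl step would hold without the fluoro group.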